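Swapping 4-methylpiperazin-1-yl for ethoxy on a carbonyl carbon

The compounds below may be only part of what the source reports. "The series", "measured", "known", "first", "only" and "open" are said of these compounds alone.

Compound 1 `CN1CCN(C(=O)/C=C/c2ccncc2-c2ccc3ccccc3c2)CC1` was tested in a functional assay on MCF7 cells (Homo sapiens) for inhibition, read by sulforhodamine B assay, with a stated time of 72 h; a higher number here means a weaker inhibitor of growth, a lower number a stronger inhibitor of growth. There, compound 1 gives > 10000 nM, which is a limit and not a number. That places compound 1 at the limit of > 10000 nM in this assay, at which 1 of the 3 values shown sits.

Two related compounds gave real numbers in this assay: compound 2 `CCOC(=O)/C=C/c1ccncc1-c1ccc2c(cnn2C)c1` gives 7320 nM, and compound 3 `CNC(=O)/C=C/c1ccncc1-c1ccc2cc[nH]c2c1` gives 9230 nM.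

Compound 4 `CCOC(=O)/C=C/c1ccncc1-c1ccc2ccccc2c1` keeps the core of compound 1 and changes one place: ethoxy in place of 4-methylpiperazin-1-yl on a carbonyl carbon. Ethoxy takes the place of 4-methylpiperazin-1-yl on a carbonyl carbon, so (4-methylpiperazin-1-yl)carbonyl becomes ethoxycarbonyl. For the measured compounds named here, no measured pair shows this change directly, so the size of the step remains uncertain.

Compound 2 carries the same ethoxycarbonyl group and gives 7320 nM, so a modest gain in growth inhibition is expected in this assay, rather than a large jump. The expected step is an at least 1.6-fold lower number from compound 1 to compound 4 (0.22 log units; that floor lies within the scatter). For compound 4 the estimated value is 6000 nM, with an expected range of 2500 nM to 10000 nM.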

Compound 4, concentration for 50% growth inhibition: 8320 nM
Compound 4: the middle estimate sits 1.4-fold (0.14 log units) below what was measured; the range from low to high includes it.
By their numbers in this assay, from the lowest: compounds 2, 4 and 3 (each within the scatter of the next). At a limit, above all of these: compound 1.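

On the carbonyl carbon, ethoxy in place of 4-methylpiperazin-1-yl gives, in this assay, an at least 1.2-fold lower number from compound 1 to compound 4 (0.07 log units; that floor lies within the scatter). With the ethoxycarbonyl group, the core of compound 1 now has a real number, as compound 4 gives 8320 nM, so further changes at this place can be measured from it. The step can be stated only as a floor, and its true size stays unknown, because compound 1 stands at a limit: the limit of > 10000 nM in this assay, at which 1 of the 4 values shown sits.

The compounds shown leave open whether a carboxylic acid or a longer chain such as butoxy on the same carbonyl carbon would give a lower number in this assay. They also do not separate how much of the step comes from losing the ring of 4-methylpiperazin-1-yl and how much from gaining the oxygen of ethoxy.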